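Swapping an Aromatic Ring for Cyclopentyl in a Toxicity Test

This account rests on a few compounds, and the source may have more. Where it says the series, first, only, none or still open, it means among the compounds named here.

Compound 3 `COc1ccc(-c2cnc(NC(=O)c3ccccc3C)n2C)cc1` carries a 2-methylphenyl group on its carbonyl carbon. In a toxicity assay on THP-1 cells (Homo sapiens) for inhibition (on this read-out lower numbers stand for higher toxicity in this test and higher numbers for lower toxicity in this test), compound 3 gives > 100000 nM, which is a limit of the test rather than a number. Two related compounds share its core and differ only in the group on that carbonyl carbon: compound 1 `COc1ccc(-c2cnc(NC(=O)c3cccnc3)n2C)cc1` and compound 2 `COc1ccc(-c2cnc(NC(=O)c3ccno3)n2C)cc1`. In this assay compound 1 gives > 100000 nM, again a limit. In this assay compound 2 gives > 100000 nM, also a limit. Because of the limit of > 100000 nM in this assay, at which 3 of the 3 values shown sit, none of the steps between these three can be read: a step that the two limits leave unreadable from compound 1 to compound 2, a step that the two limits leave unreadable from compound 1 to compound 3 and a step that the two limits leave unreadable from compound 2 to compound 3. Compound 4 `COc1ccc(-c2cnc(NC(=O)C3CCCC3)n2C)cc1` is the unmeasured partner of compound 3, and the change is cyclopentyl in place of 2-methylphenyl on a carbonyl carbon. Among the measured compounds shown here, no measured step bears on this change, since every step so far is unreadable, and the three measured compounds give nothing beyond their common limit. The expectation for compound 4 is therefore that it stays near that limit, meaning an estimated step of a number no higher from compound 3 to compound 4 (the limit leaves the size open) in this assay. Compound 4 is estimated at 100000 nM, with a range from 40000 nM to 250000 nM.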

Compound 4, half-maximal cytotoxic concentration: > 100000 nM
Compound 4 ended at the assay's limit; the forecaster's own chance of this, stated with the estimate: 85%; the middle value sits exactly at the limit.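

Among the compounds shown here, no step from compound 1, compound 2 or compound 3 to compound 4 can be read in this assay, because all four compounds stop at the same limit of the test: the limit of > 100000 nM in this assay, at which 4 of the 4 values shown sit. The compounds shown leave open whether any group on the carbonyl carbon changes toxicity in this assay at all.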